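This account rests on a few compounds, and the source may have more. Where it says the series, first, only, none or still open, it means among the compounds named here.

Measured compounds in an assay on isolated protein for inhibition of Apoptosis regulator Bcl-2 (Homo sapiens), read by fluorescence polarization; on this read-out lower numbers stand for stronger inhibition and higher numbers for weaker inhibition:
- compound 1 `O=C(O)c1ccc(COc2ccc(/C=C3\SC(=S)N(c4ccc(Cl)cc4)C3=O)cc2)cc1` gives a limit, > 10000 nM
- compound 2 `O=C(O)c1ccc(COc2ccc(/C=C3\SC(=S)N(c4ccc(Br)cc4)C3=O)cc2)cc1` gives 610 nM

Compound 2 holds the only number shown; the other value in this assay is a limit. For the measured compounds named here, the single measured step, an at least 16-fold lower number from compound 1 to compound 2 (1.21 log units; beyond the scatter), is large and rests on (the limit of > 10000 nM in this assay, at which 1 of the 2 values shown sits), so its true size is unknown. Compound 3 `O=C(O)c1ccc(COc2ccc(/C=C3\SC(=S)N(c4ccc(I)cc4)C3=O)cc2)cc1` differs from compound 2 by iodo in place of bromo on an aromatic carbon. Only the halogen swap from chloro to bromo bears on this move; it gave a sharp gain, but from a limit. A modest gain at most is expected: a 1.5-fold lower number from compound 2 to compound 3 (0.18 log units; within the scatter). For compound 3 the estimate is 400 nM, expected between 100 nM and 2500 nM.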

Compound 3, inhibition constant: 4300 nM
Compound 3: the middle estimate sits 11-fold (1.03 log units) below what was measured; measured number above the stated range.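

In this assay, the change from 4-bromophenyl to 4-iodophenyl gives a 7.0-fold higher number from compound 2 to compound 3 (0.85 log units; beyond the scatter), so the gain from chloro to bromo does not carry on to iodo, and this position does not follow halogen order in a single direction. Iodo still compares favourably with chloro, an at least 2.3-fold lower number from compound 1 to compound 3 (0.36 log units; beyond the scatter), and compound 2 holds the lowest number of the three. Compound 1 is a limit, so the true size of both steps from it stays unknown: the limit of > 10000 nM in this assay, at which 1 of the 3 values shown sits.

Open, going by these compounds, is whether a methyl, methoxy or nitrile group at this position would match bromo or fall away as chloro and iodo do.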